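Fluoro to trifluoromethyl: a small clearance step expected

The compounds below may be only part of what the source reports. "The series", "measured", "known", "first", "only" and "open" are said of these compounds alone.

Readings in an ADME assay on microsomes from liver (Homo sapiens) for metabolic stability (on this read-out higher numbers stand for fast clearance and lower numbers for slow clearance), for three compounds
- compound 1 `O=C(O)CCNC(=O)c1ccc(C(Oc2ccc(-n3cc(C(F)(F)F)cn3)cc2)C2CC2)cc1` gives < 8 mL/min/kg (a limit)
- compound 2 `CCC(Oc1ccc(-n2cc(C(F)(F)F)cn2)cc1)c1ccc(C(=O)NCCC(=O)O)cc1` gives < 8 mL/min/kg (a limit)
- compound 3 `CCCC(Oc1ccc(-n2cc(F)cn2)cc1)c1ccc(C(=O)NCCC(=O)O)cc1` gives 12 mL/min/kg (a number)

Compound 3 is the only one of the three with a true number, and in this assay compound 3 stands at 12 mL/min/kg on this scale. The other two readings rest on the limit of < 8 mL/min/kg in this assay, at which 2 of the 3 values shown sit, and are not numbers.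

Compound 4 `CCCC(Oc1ccc(-n2cc(C(F)(F)F)cn2)cc1)c1ccc(C(=O)NCCC(=O)O)cc1` differs from compound 3 in one group: trifluoromethyl in place of fluoro on an aromatic carbon (trifluoromethyl in place of fluoro on an aromatic carbon of a five-membered aromatic ring with 2 nitrogen).

For the measured compounds named here, no measured pair shows this swap directly. Going by the values given here, the one measured step, a step that the two limits leave unreadable from compound 1 to compound 2, concerns a different group and gives no size to borrow. The indirect evidence is that compound 1 and compound 2 both carry 4-(trifluoromethyl)-1H-pyrazol-1-yl, and both rest at the limit of < 8 mL/min/kg in this assay, at which 2 of the 3 values shown sit, in this assay. This points to slower clearance rather than faster, though only weakly.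

The expected change is a 1.3-fold lower number from compound 3 to compound 4 (0.12 log units; within the scatter) (small, and possibly no more than the scatter).

For compound 4 the estimate is 9 mL/min/kg with an expected range from 5 mL/min/kg to 15 mL/min/kg and a real chance that it turns out to be only a limit.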

Compound 4, clearance: 16 mL/min/kg
Estimate against measurement, compound 4: 1.8-fold (0.25 log units) below; measured number outside the range, above it.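

In this assay, the swap from 4-fluoro-1H-pyrazol-1-yl to 4-(trifluoromethyl)-1H-pyrazol-1-yl now has a direct reading, a 1.3-fold higher number from compound 3 to compound 4 (0.12 log units; within the scatter), so on the compounds with a propyl chain the two groups cannot be told apart in this assay. Trifluoromethyl alone therefore does not settle the reading, since compound 4 carries it and still gives a true number, and the steps of an at least 2.0-fold higher number from compound 2 to compound 4 (0.30 log units; that floor lies within the scatter) and an at least 2.0-fold higher number from compound 1 to compound 4 (0.30 log units; that floor lies within the scatter) hint that the group on the saturated chain carbon may count, though neither floor lies beyond the scatter. Compound 1 and compound 2 each give only a limit, not a number, so the step between them cannot be read: the limit of < 8 mL/min/kg in this assay, at which 2 of the 4 values shown sit.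

From the compounds shown here alone, what the same swap does when ethyl or cyclopropyl sits on the chain carbon stays open, and so does the true size of any effect of that chain group. Also open, going by these compounds, is how this assay would respond to a nitrile or an amine on this aromatic carbon of the five-membered ring, or to a chain longer than propyl.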